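Amide chain length in a shared-core series: compound 3

The compounds below may be only part of what the source reports. "The series", "measured", "known", "first", "only" and "open" are said of these compounds alone.

In an assay on isolated protein for inhibition of Amine oxidase [flavin-containing] B (Homo sapiens), read by fluorescence and spectrophotometry (a higher number here means a weaker inhibitor, a lower number a stronger inhibitor), compound 1 `O=C(NCc1cn(Cc2ccc3oc(-c4ccccc4)cc(=O)c3c2)nn1)c1ccccc1` gives 15600 nM. Compound 2 `O=C(CCCCc1cn(Cc2ccc3oc(-c4ccccc4)cc(=O)c3c2)nn1)Nc1ccc(F)cc1` gives 15600 nM in this assay, level with compound 1 at the digits shown, within the scatter. Compound 3 `O=C(CCc1cn(Cc2ccc3oc(-c4ccccc4)cc(=O)c3c2)nn1)Nc1ccccc1` differs from compound 2 by phenylcarbamoyl in place of 2-((4-fluorophenyl)carbamoyl)ethyl on a saturated chain carbon, two bonds along the chain from an aromatic carbon, so the amide sits nearer the shared core and the fluorine is gone. Among the compounds with values here, no measured pair isolates either part of this change; compound 1 and compound 2 merely show that a short aroyl amide and a longer anilide chain give the same reading. The step from compound 2 to compound 3 is therefore expected to be small, a 1.0-fold lower number from compound 2 to compound 3 (0.02 log units; within the scatter), none beyond the scatter in either direction. Compound 3 is estimated at 15000 nM, with a range of 5000 nM to 45000 nM.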

Compound 3, half-maximal inhibitory concentration: 15600 nM
Beside the measured number, compound 3's estimate is 1.0-fold (0.02 log units) below it; measured number inside the range.
By their numbers in this assay, from the lowest: compounds 1, 2 and 3 (each within the scatter of the next).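

In this assay, phenylcarbamoyl in place of 2-((4-fluorophenyl)carbamoyl)ethyl on a saturated chain carbon, two bonds along the chain from an aromatic carbon, gives no change at the digits printed from compound 2 to compound 3 (within the scatter), and (phenylcarbamoyl)methyl in place of benzamido on a saturated chain carbon bound to an aromatic carbon gives no change at the digits printed from compound 1 to compound 3 (within the scatter). Three amide side chains now read alike, so dropping the fluorine and shortening the chain together leaves the reading unmoved. Nothing at hand explains this reading.

The separate contributions of the fluorine and the chain length stay unresolved, since the two always change together here. From the compounds shown here alone, whether an amine or a carboxylic acid at the chain end would move the number remains open.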